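Amino to chloro: a small step expected

A few compounds are considered here, and "the series" means these few. Any claim that something is new, unique, unknown or untested is made for them only; others in the source may bear on it.

In a functional assay on HL-60 cells (Homo sapiens) for cytotoxicity, read by MTT assay, with a stated time of 72 h (on this read-out higher numbers stand for weaker inhibition and lower numbers for stronger inhibition), compound 1 (`O=S(=O)(c1ccccc1)c1nc2ccccc2nc1Nc1ccc(Cl)cc1`) gives 1920 nM and compound 2 (`Cc1ccc(S(=O)(=O)c2nc3ccccc3nc2Nc2ccc(N)cc2)cc1`) gives 1220 nM as the lower of the two numbers, though these values lie within the scatter of each other. Compound 3 (`Cc1ccc(S(=O)(=O)c2nc3ccccc3nc2Nc2ccc(Cl)cc2)cc1`) differs from compound 2 by chloro in place of amino on an aromatic carbon, para to a large group (chloro in place of amino on an aromatic carbon). For the measured compounds named here, no measured pair shows this change alone. Compound 1 also carries the (4-chlorophenyl)amino group and gives 1920 nM here, which points to no shift beyond the scatter. The expected step of a 1.2-fold higher number from compound 2 to compound 3 (0.09 log units; within the scatter) in this assay is therefore small, towards a slightly higher number. For compound 3 the estimate is 1500 nM with an expected range of 600 nM to 3800 nM in this measurement.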

Compound 3, half-maximal inhibitory concentration: 17500 nM
Beside the measured number, compound 3's estimate is 12-fold (1.07 log units) below it; the whole stated range lies below it.
By their numbers in this assay, from the lowest: compounds 2 and 1 (each within the scatter of the next); then compound 3.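

In this assay, chloro in place of amino on this aromatic carbon gives a 14-fold higher number from compound 2 to compound 3 (1.16 log units; beyond the scatter), so the position is far from indifferent to this change. With the (4-chlorophenyl)amino group held constant, methyl in place of hydrogen on an aromatic carbon gives a 9.1-fold higher number from compound 1 to compound 3 (0.96 log units; beyond the scatter), showing that a change elsewhere also moves the number. Nothing available explains either step.

On these data alone, it remains open how a methoxy or hydroxyl group would read at this position. The compounds shown also leave open whether the amino-to-chloro step keeps its size without the methyl group.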